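Isopropyl for methoxy on the anilino ring of compound 2

The source may hold more compounds than are shown below. What is called first, only, known or untested is meant among the compounds shown, and "the series" means these compounds.

In a functional assay on MDA-MB-468 cells (Homo sapiens) for antiproliferative activity, read by MTT assay, with a stated time of 24 h (a higher number here means a weaker inhibitor, a lower number a stronger inhibitor), compound 2 `CNC(=O)c1ccccc1Oc1nc(Nc2cccc(OC)c2)ncc1Br` gives 17800 nM, the lowest of the two numbers recorded so far. Within the data shown here, its only neighbour, compound 1 `CNC(=O)c1ccccc1Oc1nc(Nc2cccc(C(F)(F)F)c2)ncc1Br`, gives 32800 nM in this assay, and the move between them, a 1.8-fold lower number from compound 1 to compound 2 (0.27 log units; within the scatter), exchanged a trifluoromethyl for a methoxy group and stayed within the scatter, so the two compounds cannot be ranked against each other.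

Compound 3 `CNC(=O)c1ccccc1Oc1nc(Nc2cccc(C(C)C)c2)ncc1Br` takes the next step from compound 2: isopropyl in place of methoxy on an aromatic carbon, on an aromatic carbon of a six-membered aromatic ring of carbon only, meta to a large group. Among the measured compounds shown here, the single measured step, from compound 1 to compound 2, bears on it only loosely: it showed that replacing one substituent at this position with another left the number within the scatter. For the measured compounds named here, no measured step removes the methoxy oxygen in favour of a carbon-only group, so the data give no direct guide.

The step to compound 3 is therefore expected to be a 1.2-fold higher number from compound 2 to compound 3 (0.09 log units; within the scatter), with no shift beyond the scatter. Compound 3 is estimated at 22000 nM in this assay, within a range from 8000 nM to 60000 nM.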

Compound 3, half-maximal inhibitory concentration: 19500 nM
Estimate against measurement, compound 3: 1.1-fold (0.05 log units) above, within the range that was stated.
By their numbers in this assay, from the lowest: compounds 2, 3 and 1 (each within the scatter of the next).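

In this assay, the exchange of methoxy for isopropyl, a 1.1-fold higher number from compound 2 to compound 3 (0.04 log units; within the scatter), shows that a carbon-only group with no hydrogen-bond acceptor can stand at this place on the aromatic ring without the number leaving the scatter, something the earlier pair, which held only trifluoromethyl and methoxy, did not show. The other new step, a 1.7-fold lower number from compound 1 to compound 3 (0.23 log units; within the scatter), also stays within the scatter, so trifluoromethyl, methoxy and isopropyl cannot be ranked against one another at this position, and none of the three compounds stands apart from the others in this assay. Nothing available bears on why these three groups give numbers within the scatter of one another.

All three compounds differ only in this one group, so the shown data say nothing about how a primary amine, a carboxylic acid or a longer chain such as n-butyl would read at the same place. They also leave open whether any of these groups would move the number beyond the scatter, and what a change elsewhere on the shared core would do.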